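Urea series on the shared core: aryl versus benzyl nitrogen substituent

The source may report more compounds than this note shows. Statements on the series, on what has been measured and on what is new or still open speak of the compounds shown alone.

Of the compounds shown here, two of this set have been measured in a functional assay on T98G cells (Homo sapiens) for inhibition, read by MTT assay, with a stated time of 72 h; a higher number here means a weaker inhibitor, a lower number a stronger inhibitor. Compound 1 `CC1(C)CC(NC(=O)Nc2ccccc2Cl)c2cc(Br)ccc2O1` gives 11000 nM. Compound 2 `CC1(C)CC(NC(=O)NCc2ccccc2)c2cc(F)ccc2O1` gives 49000 nM, the highest of the two numbers; its nearest neighbour is compound 1, a gap beyond the usual scatter. Compound 3 `CC1(C)CC(NC(=O)Nc2ccccc2Cl)c2cc(F)ccc2O1` is not yet measured; it differs from compound 2 as follows: 2-chlorophenyl in place of benzyl on an amide-type nitrogen. The change is expected to lower the number, since compound 1, which already carries the 2-chlorophenyl group, sits at 11000 nM. The expected step is a 3.3-fold lower number from compound 2 to compound 3 (0.51 log units; beyond the scatter), so compound 3 is estimated at 15000 nM, within 5000 nM to 50000 nM.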

Compound 3, half-maximal inhibitory concentration: 27000 nM
For compound 3 the middle estimate is 1.8-fold (0.26 log units) below the measured one; low and high end bracket the measured number.
By their numbers in this assay, from the lowest: compound 1; then compounds 3 and 2 (each within the scatter of the next).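

In this assay, 2-chlorophenyl in place of benzyl on the amide-type nitrogen gives a 1.8-fold lower number from compound 2 to compound 3 (0.26 log units; within the scatter), so this change does not separate the two compounds when fluoro is held constant. Fluoro in place of bromo on the aromatic carbon gives a 2.5-fold higher number from compound 1 to compound 3 (0.39 log units; beyond the scatter), making the halogen change, not the nitrogen substituent change, the step that exceeds the scatter. Nothing measured here gives a cause for either step. Open, from the compounds shown here alone, is how a methoxy group or chloro on that aromatic carbon would read, and whether a cyclohexyl or phenethyl group on the amide-type nitrogen would give a step beyond the scatter.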